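The source may report more compounds than this note shows. Statements on the series, on what has been measured and on what is new or still open speak of the compounds shown alone.

Measured so far:
compound 1 `COc1cccc(-c2cc(-c3cc(C(C)C)c(O)cc3C)[nH]c(=O)c2C#N)c1`: 30%
compound 2 `COc1ccc(-c2cc(-c3cc(C(C)C)c(O)cc3C)[nH]c(=O)c2C#N)cc1`: 35%
compound 3 `COc1cc(OC)c(-c2cc(-c3cc(C(C)C)c(O)cc3C)[nH]c(=O)c2C#N)c(OC)c1`: 52.6%

In a functional assay for inhibition, tested at 40 ug/mL (on this read-out lower numbers stand for a weaker effect and higher numbers for a stronger effect at the one concentration tested), compound 2 stands in the middle of the three numbers: the gap to compound 1 lies within the scatter, while compound 3 sits beyond the scatter on the higher side. Among the measured compounds shown here, the one single-place step known, a number 5 percentage points higher from compound 1 to compound 2 (within the scatter), is a small one. Compound 4 `Cc1cc(O)c(C(C)C)cc1-c1cc(-c2ccc(N(C)C)cc2)c(C#N)c(=O)[nH]1` differs from compound 2 in one place: dimethylamino in place of methoxy on an aromatic carbon. For the measured compounds named here, no measured step swaps methoxy for dimethylamino, and the only related step, a number 5 percentage points higher from compound 1 to compound 2 (within the scatter), stayed within the scatter. A change of no more than the scatter is therefore expected, a number 3 percentage points higher from compound 2 to compound 4 (within the scatter). Compound 4 is estimated at 38%, with a range from 22% to 55%.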

Compound 4, a percentage reported as inhibition, at one concentration (the size of the read-out at that concentration, not a potency): 43%
The estimate for compound 4 lay 5 percentage points below the measured number, within the range that was stated.
By their numbers in this assay, from the lowest: compounds 1, 2, 4 and 3 (each within the scatter of the next, the first and the last beyond it).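

In this assay dimethylamino in place of methoxy, para to a large group, gives a number 8 percentage points higher from compound 2 to compound 4 (within the scatter) and so this position takes a nitrogen-linked group with no change that stands out from the scatter. Among the compounds shown here, the wider swap of 3-methoxyphenyl for 4-(dimethylamino)phenyl gives a number 13 percentage points higher from compound 1 to compound 4 (beyond the scatter) and is the first single-place step here to pass the scatter, though only modestly. Nothing available explains either step. Still open, as far as these compounds go, is how a primary amine, a carboxylic acid or a longer chain would read at this position.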